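Methyl ester to free acid in one functional assay

This account rests on a few compounds, and the source may have more. Where it says the series, first, only, none or still open, it means among the compounds named here.

Compound 1, `COC(=O)c1c(Nc2ccc(C)cc2)sc(C(=O)c2ccc(OC)cc2)c1C`: "not active" (no number reported)
Compound 2, `COC(=O)c1c(Nc2ccc(F)cc2)sc(C(=O)c2ccc(OC)cc2)c1C`: 15.2%

In a functional assay, with a stated time of 150 min, tested at 15 ug/mL (a higher number here means a stronger effect of the compound at the concentration tested, a lower number a weaker effect), compound 1 gives "not active" (no number reported), with no number behind that report. Compound 2 gives 15.2% in this assay, a low read-out. So no single number fixes where compound 1 stands; it is known only as reported inactive, and its closest measured relative compound 2 also sits low. Whether the two are apart or alike cannot be told from these two entries.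

Compound 3, `COc1ccc(C(=O)c2sc(Nc3ccc(C)cc3)c(C(=O)O)c2C)cc1`, differs from compound 1 in one place: hydrogen in place of methyl on an oxygen next to a carbonyl group. Everything else in the two structures is the same. Going by the values given here, no step between two measured compounds shows what this exchange does in this assay, so the size of its effect is open. Given that compound 1 is reported without a number and compound 2 reads low, no step beyond the scatter is expected in either direction for compound 3. Compound 3 is therefore expected to show about 8% in this assay, estimated to fall between 0% and 25%, with a real chance that it too is reported only as inactive.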

Compound 3, a percentage reported as activity, at one concentration (the size of the read-out at that concentration, not a potency): "not active" (no number reported)
For compound 3 the study gives words and no number; no gap can be computed for the estimate.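

Compound 3, like compound 1, is reported in this assay only as inactive, so no step can be read between compound 1 and compound 3. No measured property bears on this result. The compounds shown leave open what the change from methoxycarbonyl to carboxy does in this assay when both partners carry a number.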